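The source may report more compounds than this note shows. Statements on the series, on what has been measured and on what is new or still open speak of the compounds shown alone.

Among the three compounds measured so far, compound 3 `Cc1cc(C(=O)Nc2cccc(NC(=O)COc3ccc4c(=O)ccoc4c3)c2)no1` stands lowest: in an assay on isolated protein for inhibition of Rho-associated protein kinase 2 (Homo sapiens), read by scintillation counting, radiometric assay and 33P incorporation, with a stated time of 40 min, in the presence of a further agent that is not named here (a lower number here means a stronger inhibitor, a higher number a weaker inhibitor), compound 3 gives 5 nM. Compound 1 `CCCc1ccc(C(=O)Nc2cccc(NC(=O)COc3ccc4c(=O)ccoc4c3)c2)cc1` gives 14 nM and compound 2 `O=C(COc1ccc2c(=O)ccoc2c1)Nc1cccc(NC(=O)c2ccc([N+](=O)[O-])cc2)c1` gives 15 nM. The steps of a 2.8-fold lower number from compound 1 to compound 3 (0.45 log units; beyond the scatter) and a 3.0-fold lower number from compound 2 to compound 3 (0.48 log units; beyond the scatter) are both modest but beyond the scatter, whereas a 1.1-fold higher number from compound 1 to compound 2 (0.03 log units; within the scatter). Compound 4 `O=C(COc1ccc2c(=O)ccoc2c1)Nc1cccc(NC(=O)c2ccc(C(=O)O)cc2)c1` differs from compound 3 by 4-carboxyphenyl in place of 5-methyl-1,2-oxazol-3-yl on a carbonyl carbon. For the measured compounds named here, this reverses the kind of change seen in those two steps, restoring a six-membered carbon ring with one substituent, as in compound 1 and compound 2; no measured step covers the carboxy group itself. Compound 4 is therefore expected to show a modestly higher number, a 3.0-fold higher number from compound 3 to compound 4 (0.48 log units; beyond the scatter). Compound 4 is estimated at 15 nM, within 6 nM to 45 nM.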

Compound 4, half-maximal inhibitory concentration: 2030 nM
Estimate against measurement, compound 4: 140-fold (2.13 log units) below, and the stated range ends below it.
By their numbers in this assay, from the lowest: compound 3; then compounds 1 and 2 (each within the scatter of the next); then compound 4.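

Carboxy on this aromatic ring is far less tolerated than the propyl and nitro groups, which gave matching numbers: carboxy in place of nitro gives a 140-fold higher number from compound 2 to compound 4 (2.13 log units; beyond the scatter) and carboxy in place of propyl gives a 150-fold higher number from compound 1 to compound 4 (2.16 log units; beyond the scatter) in the same series. Replacing the 5-methyl-1,2-oxazol-3-yl gives a 410-fold higher number from compound 3 to compound 4 (2.61 log units; beyond the scatter) and is the largest step, yet compound 1 and compound 2 carry a six-membered ring too, so the loss follows the carboxy group, not the ring. Nothing available explains this loss.

Open, going by these compounds, is whether a methyl ester or a primary amide in place of the carboxy would return to the numbers of compound 1 and compound 2.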